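Ester to methyl(phenyl)carbamoyl on a shared quinoline-free core

A few compounds are considered here, and "the series" means these few. Any claim that something is new, unique, unknown or untested is made for them only; others in the source may bear on it.

Of the compounds shown here, three have been measured so far in an assay on brain with Translocator protein (Rattus norvegicus) as the target; on this read-out lower numbers stand for stronger inhibition and higher numbers for weaker inhibition. Compound 1 `CCN(Cc1ccccc1)Cc1ccccc1C(=O)N(CC)CC` gives 8210 nM. Compound 3 `CCOC(=O)c1c(Cl)nc2ccccc2c1-c1ccccc1` gives 3700 nM. Compound 2 `CCOC(=O)c1c(CN(CC)Cc2ccccc2)nc2ccccc2c1-c1ccccc1` gives 700 nM, the lowest of the three numbers; its gap to compound 3 and its gap to compound 1 both lie beyond the scatter of repeated measurements, so compound 2 stands as the strongest inhibitor among the compounds measured.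

Compound 4 `CCN(Cc1ccccc1)Cc1nc2ccccc2c(-c2ccccc2)c1C(=O)N(C)c1ccccc1` has not yet been measured. It differs from compound 2 in one place: methyl(phenyl)amino in place of ethoxy on a carbonyl carbon. Everything else in the shared core, including the benzyl(ethyl)aminomethyl group and the phenyl on the core, is kept.

Among the measured compounds shown here, no pair of measured compounds differs in exactly this way, so there is no measured step to lean on. For the measured compounds named here, the only anchor is the value of compound 2 in this assay, which is already the best of the set. He expects the change to lower the number further, by a step beyond the scatter, estimated as a 12-fold lower number from compound 2 to compound 4 (1.07 log units; beyond the scatter). Compound 4 is therefore expected to give about 60 nM in this assay, with a plausible range from 6 nM to 600 nM.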

Compound 4, half-maximal inhibitory concentration: 1320 nM
Estimate against measurement, compound 4: 22-fold (1.34 log units) below, outside the stated range (above it).
By their numbers in this assay, from the lowest: compounds 2 and 4 (each within the scatter of the next); then compound 3; then compound 1.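

In this assay, among the compounds shown here, methyl(phenyl)amino in place of ethoxy on a carbonyl carbon gives a 1.9-fold higher number from compound 2 to compound 4 (0.28 log units; within the scatter) and is the first single change measured at this place, with the benzyl(ethyl)aminomethyl group and the phenyl on the shared core kept. The earlier compounds shown here could not show that this place accepts a larger group carrying a six-membered aromatic ring of carbon only, yet here the exchange of ethoxycarbonyl for methyl(phenyl)carbamoyl leaves the two numbers indistinguishable within the usual scatter. No other measurement bears on why the number holds across this change.

This single pair cannot show whether the methyl or the phenyl of the new group matters more, or whether the outcome would extend to a different shared core. A smaller amide such as dimethylamino on the same carbonyl carbon, or a carboxylic acid in place of the ester, would test how much freedom this place really has.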